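Replacing ethoxy with methyl: notes on the series

This account rests on a few compounds, and the source may have more. Where it says the series, first, only, none or still open, it means among the compounds named here.

Values from a functional assay on NALM-6 cells (Homo sapiens) for cytotoxicity, with a stated time of 72 h (on this read-out higher numbers stand for an effect only at larger amounts of compound and lower numbers for an effect already at smaller amounts), follow, each one a limit and not a number:
compound 1 `C=C[C@@](C)(/C=C/c1ccc(OCc2ccccc2)cc1)CCC=C(C)C` gives > 43400 nM as a limit
compound 2 `COc1ccc(/C=C/[C@@](C)(/C=C/c2ccc(O)cc2)CCC=C(C)C)cc1` gives > 43400 nM as a limit
compound 3 `CCOc1ccc(/C=C/[C@@](C)(/C=C/c2ccc(O)cc2)CCC=C(C)C)cc1` gives > 43400 nM as a limit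

Compound 3 stands at a limit, > 43400 nM on this read-out. The evidence so far amounts to the limit of > 43400 nM in this assay, at which 3 of the 3 values shown sit, and nothing more.

Compound 4 `CC(C)=CCC[C@@](C)(/C=C/c1ccc(C)cc1)/C=C/c1ccc(O)cc1` is the next to consider. The change is methyl in place of ethoxy on an aromatic carbon in all, methyl in place of ethoxy on an aromatic carbon, para to a large group.

a step that the two limits leave unreadable from compound 2 to compound 3 is the one measured step near this change. It alters the chain on the same oxygen and gives no size to carry over, so the series offers no direction for the new step.

Given that compound 3 shows > 43400 nM as a limit, compound 4 is expected to stay at the limit in this assay as well. The expected step is a step that the limit leaves unreadable from compound 3 to compound 4 as an estimate resting on limits alone. For compound 4 the estimated value is 45000 nM with an expected range from 15000 nM to 90000 nM in this estimate.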

Compound 4, half-maximal effective concentration: > 43400 nM
Compound 4: no number, only a limit; the forecaster's own chance of this, stated with the estimate: 75%; the middle value does not contradict the limit.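

In this assay compound 4 gives > 43400 nM, which is a limit and not a number. Among the compounds shown here, no step from compound 2 or compound 3 to compound 4 can be read, and the series stands thus: the limit of > 43400 nM in this assay, at which 4 of the 4 values shown sit. The compounds shown leave open what actual values these compounds have and whether methyl, methoxy and ethoxy differ at all.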